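Solubility limit in the series and a pyridinyl swap

This account rests on a few compounds, and the source may have more. Where it says the series, first, only, none or still open, it means among the compounds named here.

Compound 1 `CCCCCNC(=O)n1cc(-c2ccccc2)oc1=O`: < 1000 nM (a limit)
Compound 2 `COc1cccc(-c2cn(C(=O)NCCCCc3ccccc3)c(=O)o2)c1`: < 1000 nM (a limit)

In a physicochemical assay for solubility, read by HPLC, in phosphate buffer, measured as kinetic solubility, with a stated time of 1 h, at pH 7.4, tested at 250 uM (a higher number here means a more soluble compound, a lower number a less soluble compound), compound 2 gives < 1000 nM, which is a limit and not a number. Compound 1 gives < 1000 nM, which is also a limit. Among the measured compounds shown here, the series so far therefore rests on (the limit of < 1000 nM in this assay, at which 2 of the 2 values shown sit), and no numerical value is available for either compound.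

Compound 3 `O=C(NCCCCc1ccccc1)n1cc(-c2ccncc2)oc1=O` has pyridin-4-yl in place of 3-methoxyphenyl on an aromatic carbon, next to the ring oxygen: pyridin-4-yl in place of 3-methoxyphenyl on an aromatic carbon. The rest of compound 2 is unchanged.

For the measured compounds named here, no measured step is available to size this change. A moderate rise in this assay is expected, although another limit reading remains quite possible. This expectation is tentative, resting only on the structural change and on compound 2 giving < 1000 nM, a limit. The expected change is an at least 4.0-fold higher number from compound 2 to compound 3 (0.60 log units; beyond the scatter). For compound 3 the estimated value is 4000 nM. The expected range for compound 3 runs from 700 nM to 30000 nM.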

Compound 3, solubility: < 1000 nM
Compound 3: a limit, no number (the forecaster's own chance of this, stated with the estimate: 35%); middle value at least 4.0-fold (0.60 log units) away from the limit.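

In this assay compound 3 gives < 1000 nM, a limit and not a number. Among the compounds shown here, compound 2 also stands at a limit, so no step between compound 2 and compound 3 can be read. Left open is where any compound shown lies as an actual number in this assay, since all rest on one reading: the limit of < 1000 nM in this assay, at which 3 of the 3 values shown sit.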